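The compounds below may be only part of what the source reports. "The series", "measured", "known", "first", "only" and "open" are said of these compounds alone.

Measured so far in a functional assay on SK-OV-3 cells (Homo sapiens) for cytotoxicity, read by MTT assay, with a stated time of 48 h; a higher number here means a weaker inhibitor, a lower number a stronger inhibitor: compound 1 `O=C(/C=C/c1ccc2c(c1)B(O)OC2)c1ccco1` gives 20700 nM; compound 2 `O=C(/C=C/c1ccc2c(c1)B(O)OC2)c1cccs1` gives 10400 nM.

Compound 2 holds the lower of the two numbers seen so far, and its nearest neighbour is compound 1. Within the data shown here, the only step on record, a 2.0-fold lower number from compound 1 to compound 2 (0.30 log units; within the scatter), stays within the scatter, so the two compounds cannot be placed in any firm order on this evidence.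

Compound 3 `O=C(/C=C/c1ccc2c(c1)B(O)OC2)c1cccnc1` is the next compound in this series and has not yet been measured. Its structure differs from compound 2 in a single place: pyridin-3-yl in place of thiophen-2-yl on a carbonyl carbon. Among the measured compounds shown here, of the measured steps, only the one from compound 1 to compound 2 bears on this change, since it also exchanges one aromatic ring for another on the same carbonyl carbon, and that step was small. For the measured compounds named here, on that basis the exchange leading to compound 3 is expected to yield no step in this assay beyond the scatter, and the step of a 1.2-fold higher number from compound 2 to compound 3 (0.06 log units; within the scatter) is the estimate that follows. For compound 3 the expected value in this assay is therefore 12000 nM, with a range from 4000 nM to 40000 nM.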

Compound 3, half-maximal inhibitory concentration: 18500 nM
Compound 3: the middle estimate sits 1.5-fold (0.19 log units) below what was measured; the measured number falls inside the stated range.
By their numbers in this assay, from the lowest: compounds 2, 3 and 1 (each within the scatter of the next).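

Compound 3 extends the comparison on the carbonyl carbon beyond the five-membered aromatic rings of compound 1 and compound 2, bringing in a six-membered aromatic ring whose hetero atom is nitrogen. In this assay this exchange gives a 1.8-fold higher number from compound 2 to compound 3 (0.25 log units; within the scatter) when thiophen-2-yl leaves and a 1.1-fold lower number from compound 1 to compound 3 (0.05 log units; within the scatter) when furan-2-yl leaves, so neither the larger ring nor the different hetero atom produces a step beyond the scatter among these three compounds. The three cannot be placed in any firm order, and nothing on hand gives a reason for how closely their values lie.

What the compounds leave open is whether any group on this carbonyl carbon can move the number beyond the scatter, since all three carry a single aromatic ring with one hetero atom. A plain phenyl ring, pyridin-2-yl or pyridin-4-yl, a phenyl ring carrying an amine or a carboxylic acid, or a saturated ring such as piperidine would test this, and how far the shared core itself sets the level of these values also remains unsettled.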